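Trifluoromethoxy to Hydroxymethyl: a Solubility Expectation

A few compounds are considered here, and "the series" means these few. Any claim that something is new, unique, unknown or untested is made for them only; others in the source may bear on it.

Measured compounds:
compound 1 `Cc1nc(C#N)c(N)c2c1C(=O)N(Cc1ccccc1)C2=O` — < 5000 nM
compound 2 `Cc1noc(-c2nc(C)c3c(c2N)C(=O)N(Cc2ccc(OC(F)(F)F)cc2)C3=O)n1` — < 5000 nM

Both measured compounds were examined in a physicochemical assay for solubility, using the shake flask method, in simulated intestinal fluid, measured as kinetic solubility, with a stated time of 2 h, at 25 degrees C, at pH 6.5; a lower number here means a less soluble compound, a higher number a more soluble compound. Compound 1 returned only a limit of the assay, < 5000 nM, and no number. Compound 2 likewise returned only a limit, < 5000 nM, so its true solubility is not known beyond that. Where compound 2 stands is therefore fixed only by the limit of < 5000 nM in this assay, at which 2 of the 2 values shown sit; nothing separates it from compound 1 on the numbers available, and no step between the two is counted.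

The step under consideration leads from compound 2 to compound 3 `Cc1noc(-c2nc(C)c3c(c2N)C(=O)N(Cc2ccc(CO)cc2)C3=O)n1`. The change is hydroxymethyl in place of trifluoromethoxy on an aromatic carbon. No measured step of this kind exists among the compounds shown, so the expectation rests on the limit alone.

For compound 3 an upward step an at least 4.0-fold higher number from compound 2 to compound 3 (0.60 log units; beyond the scatter) in this assay is expected, that is, toward a more soluble compound. Compound 3 is estimated at 20000 nM, with a range from 4000 nM to 100000 nM.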

Compound 3, solubility: < 5000 nM
Compound 3: only a limit was reported (the forecaster's own chance of this, stated with the estimate: 30%); middle value at least 4.0-fold (0.60 log units) away from the limit.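

Compound 3 gives < 5000 nM and this is a limit of the assay, not a number. Among these compounds, compound 2 also stands only at a limit, so no step from compound 2 to compound 3 can be read: the limit of < 5000 nM in this assay, at which 3 of the 3 values shown sit. The compounds shown leave open how soluble each one truly is, and whether hydroxymethyl in place of trifluoromethoxy on an aromatic carbon changes the read-out at all.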